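Removing one methyl from compound 2

This account rests on a few compounds, and the source may have more. Where it says the series, first, only, none or still open, it means among the compounds named here.

Of the compounds shown here, three built on one shared core have been tested in a functional assay on PC-3 cells (Homo sapiens) for cytotoxicity, with a stated time of 48 h; a lower number here means a stronger inhibitor, a higher number a weaker inhibitor. Here compound 1 `COc1cc(OC)c(C(=O)/C=C/c2ccccc2OC)c(OC)c1` gives 8100 nM, compound 3 `COc1cc(OC)c(C(=O)/C=C/c2ccc(Br)cc2)c(OC)c1` gives 7100 nM, and compound 2 `COc1cccc(/C=C/C(=O)c2c(OC)cc(OC)cc2OC)c1` gives 3100 nM, the lowest of the three numbers. Compound 4 `COc1cccc(/C=C/C(=O)c2c(O)cc(OC)cc2OC)c1` differs from compound 2 by having hydrogen in place of methyl on an oxygen on an aromatic ring, so a methoxy becomes hydroxy: hydrogen in place of methyl on an oxygen on an aromatic ring. Going by the values given here, no measured step touches this place. The steps available change a different group and serve only as a guide to size: a 2.6-fold lower number from compound 1 to compound 2 (0.42 log units; beyond the scatter), a 2.3-fold higher number from compound 2 to compound 3 (0.36 log units; beyond the scatter) and a 1.1-fold lower number from compound 1 to compound 3 (0.06 log units; within the scatter). With no direction shown, the expected result is a 1.0-fold lower number from compound 2 to compound 4 (0.01 log units; within the scatter), within the scatter. For compound 4, the estimated value is 3000 nM, with an expected range from 1000 nM to 9000 nM.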

Compound 4, half-maximal inhibitory concentration: 7300 nM
Compound 4: the middle estimate sits 2.4-fold (0.39 log units) below what was measured; low and high end bracket the measured number.
By their numbers in this assay, from the lowest: compound 2; then compounds 3, 4 and 1 (each within the scatter of the next).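

Going by these compounds alone, the first measured change at this place, on an oxygen on an aromatic ring, weakens the compound: in this assay, hydrogen in place of methyl gives a 2.4-fold higher number from compound 2 to compound 4 (0.37 log units; beyond the scatter). So this methoxy is not a silent spot, since changing it to hydroxy moves the number beyond the scatter and leaves compound 2 with the lowest value of the four. Nothing available here explains why the change has this effect.

As far as these compounds go, whether the same change acts alike on the other methoxy groups or in compound 1 and compound 3 stays open, as does what an ethoxy or an amine would give at this place.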